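This account rests on a few compounds, and the source may have more. Where it says the series, first, only, none or still open, it means among the compounds named here.

Compound 1, whose structure is `CCOc1ccc(C(=O)/C=C/c2ccc(CC)cc2)cc1`, was tested in an assay on isolated protein for inhibition of Amine oxidase [flavin-containing] B (Homo sapiens) (a higher number here means a weaker inhibitor, a lower number a stronger inhibitor), where compound 1 gives 210 nM. Compound 2 `CCc1ccc(/C=C/C(=O)c2ccc(-n3ccnc3)cc2)cc1` shares the same core and carries a 1H-imidazol-1-yl in place of ethoxy on an aromatic carbon; in this assay compound 2 gives 320 nM, which is a 1.5-fold higher number from compound 1 to compound 2 (0.18 log units; within the scatter). Compound 3 `COc1ccc(/C=C/C(=O)c2ccc(ON=C3CCCCC3)cc2)cc1` was also tested, and for compound 3 this assay reports only a limit, < 300 nM. That is the limit of < 300 nM in this assay, at which 1 of the 3 values shown sits. Of the two plain numbers, that of compound 1 is the lowest, but its gap to compound 2 is within the scatter, so no real order between them can be read.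

Compound 4 `CCOc1ccc(C(=O)/C=C/c2ccc(Cl)cc2)cc1` differs from compound 1 by chloro in place of ethyl on an aromatic carbon. Going by the values given here, the single measured step, from ethoxy to 1H-imidazol-1-yl, touches a different part of the core and so says nothing about this swap; no measured step covers chloro in place of ethyl. With nothing pointing either way, the expected step is a 1.2-fold higher number from compound 1 to compound 4 (0.08 log units; within the scatter), no change beyond the scatter. Compound 4 is therefore estimated at 250 nM in this assay. For compound 4 the expected range runs from 90 nM to 700 nM.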

Compound 4, half-maximal inhibitory concentration: 210 nM
The estimate for compound 4 lay 1.2-fold (0.08 log units) above the measured number, and the stated range covers the measured number.
By their numbers in this assay, from the lowest: compounds 1, 4 and 2 (each within the scatter of the next).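

Placing chloro in place of ethyl on the aromatic carbon para to a large group gives, in this assay, no change at the digits printed from compound 1 to compound 4 (within the scatter). Going by these compounds alone, this is the first measured step at this position, and it shows that a single chlorine atom can stand where the two carbons of ethyl stood without moving the number beyond the scatter. Nothing measured here explains why the number holds.

Ethyl and chloro both count no hydrogen-bond donors or acceptors and no net charge, so it remains open how an amine, a carboxylic acid or a longer chain would read at this position. From the compounds shown here alone, it is also open whether chloro in place of ethyl would give the same result in compound 2, which has 1H-imidazol-1-yl in place of ethoxy.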